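The compounds below may be only part of what the source reports. "The series", "measured", "known", "first", "only" and "open" are said of these compounds alone.

Compound 1 `CS(=O)(=O)c1cnc(C(=O)CCCCCCc2ccccc2)o1`: > 10000 nM
Compound 2 `CNC(=O)c1cnc(C(=O)CCCCCCc2ccccc2)o1`: > 10000 nM

In an assay on HEK-293T cells for inhibition of diacylglycerol lipase-alpha (Homo sapiens), read by colorimetric assay (a higher number here means a weaker inhibitor, a lower number a stronger inhibitor), compound 1 gives only a limit of the assay, > 10000 nM. Compound 2 likewise gives only a limit, > 10000 nM. For the measured compounds named here, both values sit at the same place, as the limit of > 10000 nM in this assay, at which 2 of the 2 values shown sit, shows, so the one measured step cannot be read: a step that the two limits leave unreadable from compound 1 to compound 2. Compound 2 thus stands at the limit of this assay, with no number of its own.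

Compound 3 `O=C(CCCCCCc1ccccc1)c1ncc(-c2ccc(F)cc2)o1` differs from compound 2 in one place: 4-fluorophenyl in place of methylcarbamoyl on an aromatic carbon. No measured step bears on this change, and the single step that exists is itself unreadable, so neither size nor direction can be taken from the data shown. The step from compound 2 to compound 3 is therefore expected to be an at least 2.0-fold lower number from compound 2 to compound 3 (0.30 log units; that floor lies within the scatter), carrying wide uncertainty. Compound 3 is estimated at 5000 nM, within a range from 500 nM to 50000 nM.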

Compound 3, half-maximal inhibitory concentration: > 10000 nM
Compound 3: a limit, no number; the forecaster's own chance of this, stated with the estimate: 50%; middle value at least 2.0-fold (0.30 log units) away from the limit.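

Compound 3 also gives only a limit of the assay, so its steps from compound 1 and compound 2 cannot be read: the limit of > 10000 nM in this assay, at which 3 of the 3 values shown sit.

The compounds shown leave open which group at this place on the shared core, if any, would give a number of its own in this assay.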